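Amine variation on the dithiocarbamate-bearing chromenone series

This account rests on a few compounds, and the source may have more. Where it says the series, first, only, none or still open, it means among the compounds named here.

The two measured compounds share one core and differ only in the amine attached to the thiocarbonyl carbon. Compound 1 `O=c1c(CSC(=S)N2CCCCC2)coc2cc(Cl)ccc12` carries piperidin-1-yl there, and in a functional assay on LM7 cells (Homo sapiens) for antiproliferative activity, read by MTT assay, with a stated time of 72 h (on this read-out lower numbers stand for stronger inhibition and higher numbers for weaker inhibition), compound 1 gives 850 nM. Compound 2 `O=c1c(CSC(=S)N2CCCC2)coc2cc(Cl)ccc12` carries pyrrolidin-1-yl instead, and in this assay compound 2 gives 2600 nM. Going by the values given here, the single step recorded, a 3.1-fold higher number from compound 1 to compound 2 (0.49 log units; beyond the scatter), is the only guide available. On the numbers shown, compound 2 stands highest of the two, with compound 1 the nearest neighbour at a lower number beyond the scatter.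

Compound 3 `CC(C)N(C(=S)SCc1coc2cc(Cl)ccc2c1=O)C(C)C` is the next member. The change from compound 2 to compound 3 is diisopropylamino in place of pyrrolidin-1-yl on a thiocarbonyl carbon. Among the compounds with values here, no measured step exchanges a cyclic amine for an acyclic one, so the step from compound 1 to compound 2 bears on it only loosely, showing that the amine at this position moves the result by a modest amount. For compound 3 the number in this assay is therefore expected to lie near that of compound 2, the estimated step of a 1.4-fold lower number from compound 2 to compound 3 (0.16 log units; within the scatter) being no larger than the scatter in either direction. Compound 3 is estimated at 1800 nM, with a range from 600 nM to 5500 nM.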

Compound 3, half-maximal inhibitory concentration: > 25000 nM
Compound 3: only a limit was reported (the forecaster's own chance of this, stated with the estimate: 5%); middle value at least 13-fold (1.14 log units) from the limit.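

Compound 3 gives only a limit in this assay, so its entry marks a bound and not a measured number: the limit of > 25000 nM in this assay, at which 1 of the 3 values shown sits.

Even read as bounds, the new steps are of a different order from the one earlier step, a 3.1-fold higher number from compound 1 to compound 2 (0.49 log units; beyond the scatter). The change to diisopropylamino gives an at least 9.6-fold higher number from compound 2 to compound 3 (0.98 log units; beyond the scatter), and set against the piperidin-1-yl compound it gives an at least 29-fold higher number from compound 1 to compound 3 (1.46 log units; beyond the scatter). The earlier pair showed only that changing one cyclic amine for another shifts the number modestly, whereas this result shows that the amine on the thiocarbonyl carbon can decide the outcome in this assay: both cyclic amines give measured values, and the single open-chain amine gives a limit.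

The compounds shown leave open whether a smaller open-chain amine, such as dimethylamino or diethylamino, would keep a measured value, which would separate the loss of the ring from the presence of the isopropyl branches. Also open, from the compounds shown here alone, is how a larger ring such as azepan-1-yl, or a ring with a further hetero atom such as morpholin-4-yl, would compare with piperidin-1-yl and pyrrolidin-1-yl.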